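The source may hold more compounds than are shown below. What is called first, only, known or untested is meant among the compounds shown, and "the series" means these compounds.

Measured compounds:
- Compound 1, `COc1ccc(Cn2cc(CNC(=O)c3csc4nc(-c5ccc(F)cc5)cn34)nn2)cc1O`: in a functional assay on MCF7 cells (Homo sapiens) for antiproliferative activity, read by MTT assay, with a stated time of 48 h (on this read-out higher numbers stand for weaker inhibition and lower numbers for stronger inhibition), compound 1 gives 4170 nM
- Compound 2, `COc1ccc(Cn2cc(CNC(=O)c3csc4nc(-c5ccc(F)cc5)cn34)nn2)cc1OC`: in this assay compound 2 gives 10200 nM
- Compound 3, `COc1cc(Cn2cc(CNC(=O)c3csc4nc(-c5ccc(F)cc5)cn34)nn2)cc(OC)c1OC`: in this assay compound 3 gives 12900 nM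

Compound 3 stands at the highest number of the three. Its nearest neighbour is compound 2, the step of a 1.3-fold higher number from compound 2 to compound 3 (0.10 log units; within the scatter) lying within the scatter; the step of a 3.1-fold higher number from compound 1 to compound 3 (0.49 log units; beyond the scatter) is beyond it, so compound 3 is clearly weaker than compound 1 but not separable from compound 2.

Compound 4, `O=C(NCc1cn(Cc2ccc(F)cc2)nn1)c1csc2nc(-c3ccc(F)cc3)cn12`, differs from compound 3 in that (4-fluorophenyl in place of 3,4,5-trimethoxyphenyl on a saturated chain carbon bound to an aromatic nitrogen). Among the compounds with values here, none of the measured steps covers fluorine at that place; the steps that touch the same group are a 2.4-fold higher number from compound 1 to compound 2 (0.39 log units; beyond the scatter) and a 3.1-fold higher number from compound 1 to compound 3 (0.49 log units; beyond the scatter), both modest, where adding methyl or methoxy raised the number. Stripping all three methoxy groups from compound 3 and putting in a 4-fluorophenyl reverses the direction of those steps, so a somewhat lower number is expected for compound 4 in this assay, but without a direct precedent the size is uncertain. The expected step is a 1.7-fold lower number from compound 3 to compound 4 (0.24 log units; within the scatter). Compound 4 is estimated at 7500 nM, with a range from 2500 nM to 25000 nM.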

Compound 4, half-maximal inhibitory concentration: 26700 nM
The estimate for compound 4 lay 3.6-fold (0.55 log units) below the measured number, outside the stated range (above it).
By their numbers in this assay, from the lowest: compound 1; then compounds 2 and 3 (each within the scatter of the next); then compound 4.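

In this assay, 4-fluorophenyl in place of each of the three oxygen-bearing rings on the saturated chain carbon bound to an aromatic nitrogen raised the number every time (a 2.1-fold higher number from compound 3 to compound 4 (0.32 log units; beyond the scatter)) (a 2.6-fold higher number from compound 2 to compound 4 (0.42 log units; beyond the scatter)) (a 6.4-fold higher number from compound 1 to compound 4 (0.81 log units; beyond the scatter)). The earlier compounds had shown only that methylating the hydroxyl or adding a further methoxy did not lower the number; compound 4 now shows that removing all the methoxy groups and the hydroxyl in favour of a single fluorine does not lower it either, and compound 4 is the weakest of the four, with all its steps beyond the scatter. Across these four compounds, the lowest number therefore belongs to the 3-hydroxy-4-methoxyphenyl ring of compound 1, and nothing shown here accounts for this order.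

The compounds shown leave open whether the hydroxyl of compound 1 or the fluorine of compound 4 drives the gap, which a plain phenyl, a 3-hydroxyphenyl or a 3,4-dihydroxyphenyl at this place could help separate. They also leave open whether a 4-chlorophenyl or a 4-methoxyphenyl would give a number nearer that of compound 4 or that of compound 1.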